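The compounds below may be only part of what the source reports. "The series", "measured", "known", "first", "only" and "open" are said of these compounds alone.

Measured in a toxicity assay on cells (Macrophage, Mus musculus, strain BALB/c) for cytotoxicity, read by MTT assay; on this read-out higher numbers stand for weaker inhibition and lower numbers for stronger inhibition:
compound 1 `COc1cc(O)cc(O)c1C(=O)/C=C/c1ccc(C)cc1`: 16500 nM
compound 2 `COc1cc(O)cc(O)c1C(=O)/C=C/c1ccc(Cl)cc1`: 19000 nM
compound 3 `COc1cc(O)cc(O)c1C(=O)/C=C/c1ccc(F)cc1`: 28800 nM

Compound 3, at 28800 nM, lies within the scatter of both other compounds, so the three form a single group. Compound 4 `COc1ccc(/C=C/C(=O)c2c(O)cc(O)cc2OC)cc1` carries methoxy in place of fluoro on an aromatic carbon, para to a large group: methoxy in place of fluoro on an aromatic carbon. Within the data shown here, no measured compound carries this methoxy, so the closest guides are the other exchanges on an aromatic carbon: a 1.7-fold higher number from compound 1 to compound 3 (0.24 log units; within the scatter), a 1.5-fold higher number from compound 2 to compound 3 (0.18 log units; within the scatter) and a 1.2-fold higher number from compound 1 to compound 2 (0.06 log units; within the scatter). All stay within the scatter, so no change beyond the scatter is expected in this assay. The expected step is a 1.4-fold lower number from compound 3 to compound 4 (0.16 log units; within the scatter). For compound 4 the estimated value is 20000 nM, with an expected range from 9000 nM to 45000 nM.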

Compound 4, half-maximal inhibitory concentration: 166000 nM
The estimate for compound 4 lay 8.3-fold (0.92 log units) below the measured number; the whole stated range lies below it.
By their numbers in this assay, from the lowest: compounds 1, 2 and 3 (each within the scatter of the next); then compound 4.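

At this position, para to a large group, methoxy stands apart from the other three substituents in this assay. There a 5.8-fold higher number from compound 3 to compound 4 (0.76 log units; beyond the scatter) and an 8.7-fold higher number from compound 2 to compound 4 (0.94 log units; beyond the scatter) and a 10-fold higher number from compound 1 to compound 4 (1.00 log units; beyond the scatter) all lie beyond the scatter, whereas the exchanges among methyl, chloro and fluoro stayed within it. The position therefore does respond to its substituent, and this change goes towards weaker inhibition.

From the compounds shown here alone, whether the shift is peculiar to methoxy, or would also come with ethoxy or an amine here, stays open. Nothing at hand bears on what lies behind the shift.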